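Two Halogens, One Limit: From Chloro to Fluoro

This account rests on a few compounds, and the source may have more. Where it says the series, first, only, none or still open, it means among the compounds named here.

In a functional assay on SK-OV-3 cells (Homo sapiens) (on this read-out higher numbers stand for weaker inhibition of growth and lower numbers for stronger inhibition of growth), compound 1 `O=S(=O)(/C=C/c1ccc(C(F)(F)F)cc1F)Cc1ccc(Nc2ncnc3cc(Cl)ccc23)cc1` gives > 100000 nM, which is a limit and not a number. Compound 2 `O=S(=O)(/C=C/c1ccc(F)cc1Cl)Cc1ccc(Nc2ncnc3cc(Cl)ccc23)cc1` gives > 100000 nM, again a limit of the assay. So compound 2 has no exact position on the scale, and the evidence consists of the limit of > 100000 nM in this assay, at which 2 of the 2 values shown sit.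

Compound 3 `O=S(=O)(/C=C/c1ccc(F)cc1F)Cc1ccc(Nc2ncnc3cc(Cl)ccc23)cc1` changes one atom of compound 2: fluoro in place of chloro on an aromatic carbon. This places fluoro in place of chloro on an aromatic carbon, ortho to a large group and meta to a fluoro group, so that 2-chloro-4-fluorophenyl becomes 2,4-difluorophenyl.

Going by the values given here, only one measured step bears on this change, a step that the two limits leave unreadable from compound 1 to compound 2, and it offers no size to carry over. Since a step that the two limits leave unreadable from compound 1 to compound 2 has no readable size, no step beyond the scatter is expected in this assay, in either direction. The expected change is a number no higher from compound 2 to compound 3 (the limit leaves the size open). Another limit rather than a number is the likeliest report. For compound 3 the estimated value is 100000 nM, with an expected range from 30000 nM to 300000 nM.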

Compound 3, concentration for 50% growth inhibition: > 100000 nM
Compound 3: no number, only a limit; the forecaster's own chance of this, stated with the estimate: 85%; the middle value lies on the limit itself.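

Compound 3 gives > 100000 nM, which is a limit and not a number. Going by these compounds alone, no step among compound 1, compound 2 and compound 3 can be read, as all three rest on the same limit: the limit of > 100000 nM in this assay, at which 3 of the 3 values shown sit.

How strongly any of these compounds inhibits growth in this assay stays open, as does whether swapping these groups changes it at all.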